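A few compounds are considered here, and "the series" means these few. Any claim that something is new, unique, unknown or untested is made for them only; others in the source may bear on it.

Measured so far, in a functional assay on SW 1116 cells (Homo sapiens) for antiproliferative activity, read by MTT assay, with a stated time of 48 h; on this read-out higher numbers stand for weaker inhibition and lower numbers for stronger inhibition:
Compound 1, `Clc1ccc(CSc2nnc(-c3cnccn3)o2)cc1`, gives 17300 nM.
Compound 2, `Brc1ccc(CSc2nnc(-c3cnccn3)o2)cc1`, gives 14400 nM.
Compound 3, `Clc1ccccc1CSc1nnc(-c2cnccn2)n1-c1ccccc1`, gives 18100 nM.

Compound 1 and compound 2 differ by one change, (bromo in place of chloro on an aromatic carbon), and it made a step of a 1.2-fold lower number from compound 1 to compound 2 (0.08 log units; within the scatter). Compound 3 rests on a different core; the difference between the two cores is not broken down here, and its value sits close to the other two.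

Compound 4, `Brc1ccccc1CSc1nnc(-c2cnccn2)n1-c1ccccc1`, is not yet measured. It differs from compound 3 by bromo in place of chloro on an aromatic carbon. This is the same kind of change as that from compound 1 to compound 2, but the place is not identical: there the new group sat para to a large group, here it sits ortho to a large group.

Among the measured compounds shown here, since the only measured example, a 1.2-fold lower number from compound 1 to compound 2 (0.08 log units; within the scatter), stayed within the scatter, compound 4 is expected to move by about a 1.2-fold lower number from compound 3 to compound 4 (0.08 log units; within the scatter). The estimate for compound 4 is therefore 15000 nM, expected between 7000 nM and 32000 nM.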

Compound 4, half-maximal inhibitory concentration: 19400 nM
Beside the measured number, compound 4's estimate is 1.3-fold (0.11 log units) below it; the measured number falls inside the stated range.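

In this assay, putting bromo in place of chloro on the second core gives a 1.1-fold higher number from compound 3 to compound 4 (0.03 log units; within the scatter), so on this core too the swap leaves the number within the usual scatter. Set side by side, the two steps do not differ: the same change on two cores in this assay, a 1.2-fold lower number (0.08 log units; within the scatter) from compound 1 to compound 2 and a 1.1-fold higher number (0.03 log units; within the scatter) from compound 3 to compound 4, 1.3-fold (0.11 log units) apart, within the scatter of two such steps. Among the compounds shown here, this shows that the swap makes no readable difference on either core, but with only two small steps, and with the halogen in a different place in each pair, it does not show how a change with a real effect would carry from one core to the other.

Still open, on these data alone, is whether a different group on the benzyl ring, such as an amine or a carboxylic acid, would move the number at all. Also open, as far as these compounds go, is whether the two cores would then respond alike.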